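A Tert-Butyl Group Tried in Place of Ethoxy

A few compounds are considered here, and "the series" means these few. Any claim that something is new, unique, unknown or untested is made for them only; others in the source may bear on it.

Compound 1 `O=C(CCC1=CCN(CCCc2ccc(Br)cc2)C1=O)NO`: 5100 nM
Compound 2 `CCOc1ccc(CCCN2CC=C(CCC(=O)NO)C2=O)cc1`: 5100 nM

Both measured compounds share one core and differ only at one aromatic carbon. Within the data shown here, in a functional assay on HCT-15 cells (Homo sapiens) for inhibition, read by sulforhodamine B assay (on this read-out higher numbers stand for weaker inhibition of growth and lower numbers for stronger inhibition of growth), the one recorded step, no change at the digits printed from compound 1 to compound 2 (within the scatter), stayed within the scatter, so compound 2 stands level with compound 1. Compound 3 `CC(C)(C)c1ccc(CCCN2CC=C(CCC(=O)NO)C2=O)cc1` carries tert-butyl in place of ethoxy on an aromatic carbon. Among the measured compounds shown here, only that earlier step bears on this change, and it showed no movement, so no step beyond the scatter is expected here either; the expected step is no change at the digits printed from compound 2 to compound 3 (within the scatter). Compound 3 is accordingly estimated at 5100 nM, with a likely range from 2000 nM to 13000 nM.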

Compound 3, concentration for 50% growth inhibition: 5100 nM
Compound 3: middle estimate and measured number agree at the digits printed; measured number inside the range.
By their numbers in this assay, from the lowest: compounds 1, 2 and 3 (each within the scatter of the next).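

In this assay, replacing ethoxy with tert-butyl, which has one more heavy atom and no hydrogen-bond acceptor, gives no change at the digits printed from compound 2 to compound 3 (within the scatter), and replacing bromo with tert-butyl gives no change at the digits printed from compound 1 to compound 3 (within the scatter). This aromatic carbon has now held three different groups with no step beyond the scatter, so the lack of movement seen with the first swap also holds for a second, different swap. No supporting evidence is available to explain this flat result. Going by these compounds, whether it would hold with an amine or a carboxylic acid on this carbon remains open, and so does the effect of moving any group elsewhere on the ring.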